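A Side Chain Swap on Compound 2

A few compounds are considered here, and "the series" means these few. Any claim that something is new, unique, unknown or untested is made for them only; others in the source may bear on it.

Compound 1 `O=C(Nc1cc(C(F)(F)F)cc(C(F)(F)F)c1)C1CCc2ccccc2N1C(=O)c1ccccc1Cl` gives 5250 nM
Compound 2 `O=C(Nc1ccccc1O)C1CCc2ccccc2N1C(=O)c1ccccc1Cl` gives 47400 nM
Compound 3 `O=C(Nc1ccc(O)cc1)C1CCc2ccccc2N1` gives > 100000 nM

In a functional assay on MDA-MB-231 cells (Homo sapiens) for cytotoxicity, read by sulforhodamine B assay, with a stated time of 72 h (on this read-out lower numbers stand for stronger inhibition of growth and higher numbers for weaker inhibition of growth), compound 2 stands highest of the two true numbers at 47400 nM while compound 1 sits lower at 5250 nM on the same scale. The gap between these two numbers lies beyond the scatter. Compound 3 reaches only a limit of the assay, > 100000 nM and no number. Compound 4 `CCCCCCCCC(=O)N1c2ccccc2CCC1C(=O)Nc1ccccc1O` has octyl in place of 2-chlorophenyl on a carbonyl carbon of compound 2 (octyl in place of 2-chlorophenyl on a carbonyl carbon). Among the measured compounds shown here, no measured pair shows this change, so no shift beyond the scatter is expected in this assay for it. The estimated step of a 1.4-fold lower number from compound 2 to compound 4 (0.13 log units; within the scatter) stays within that scatter. Compound 4 is expected at 35000 nM within a range of 10000 nM to 100000 nM by this estimate.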

Compound 4, concentration for 50% growth inhibition: 54300 nM
Beside the measured number, compound 4's estimate is 1.6-fold (0.19 log units) below it; the measured number falls inside the stated range.
By their numbers in this assay, from the lowest: compound 1; then compounds 2 and 4 (each within the scatter of the next). At a limit, above all of these: compound 3.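

Octyl in place of 2-chlorophenyl on a carbonyl carbon gives a 1.1-fold higher number from compound 2 to compound 4 (0.06 log units; within the scatter) in this assay. Among the compounds shown here, the earlier compounds held only 2-chlorophenyl on this carbonyl or lacked the carbonyl altogether, so this is the first sign that, with the rest of compound 2 unchanged, a chain with no ring can replace that aromatic ring without a shift beyond the scatter.

Going by these compounds, whether a shorter chain, an amine or a carboxylic acid on this carbonyl would do the same stays open. Nothing at hand bears on why this step is so small.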